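Acetylating a hydroxy group in a cytotoxic lactone series

The source may hold more compounds than are shown below. What is called first, only, known or untested is meant among the compounds shown, and "the series" means these compounds.

Three related compounds have been tested in a functional assay on HEp-2 cells (Homo sapiens) for cytotoxicity, read by MTT assay; a lower number here means that less compound is needed, a higher number that more compound is needed for the effect. Compound 1 `C=C1C(=O)O[C@]2(C)CC[C@@H]1C[C@H](O)[C@@]1(C)CC[C@H](OC(C)=O)[C@@](C)(CCC2=O)O1` reaches only the assay limit: in this assay compound 1 gives < 20 ug/mL, which is a limit and not a number. Compound 2 `C=C1C(=O)O[C@]2(C)CC[C@@H]1C[C@H](OC(C)=O)[C@@]1(C)CC[C@H](O1)[C@](C)(O)CC[C@H]2OC(C)=O` likewise stops at the limit, giving < 20 ug/mL. Compound 3 `C=C1C(=O)O[C@]2(C)CC[C@@H]1C[C@H](O)[C@@]1(C)CC[C@H](O1)C(=C)CC[C@H]2OC(C)=O` also sits at the limit in this assay, with < 20 ug/mL. Compound 3 thus stands exactly where the other measured compounds stand, namely at the limit of < 20 ug/mL in this assay, at which 3 of the 3 values shown sit; no number separates the three, and nothing can be said about order among them.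

Compound 4 `C=C1C(=O)O[C@]2(C)CC[C@@H]1C[C@H](OC(C)=O)[C@@]1(C)CC[C@H](O1)C(=C)CC[C@H]2OC(C)=O` is the unmeasured neighbour of compound 3. The change is acetyl in place of hydrogen on an oxygen on a saturated carbon. Within the data shown here, with every measured compound resting at the same limit, there is no measured step to lean on. The expected step from compound 3 to compound 4 is none beyond the scatter, a step that the limit leaves unreadable from compound 3 to compound 4. Compound 4 is estimated at 10 ug/mL, within a range of 3 ug/mL to 25 ug/mL, and it is expected most likely to be reported again only as a limit.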

Compound 4, concentration for half-maximal effect: < 20 ug/mL
Compound 4 ended at the assay's limit; the forecaster's own chance of this, stated with the estimate: 70%; the middle value lies beyond the limit too.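

Among these compounds, compound 3 and compound 4 both rest at a limit and not at a number, so the change from hydroxy to acetoxy gives no step that can be read: the limit of < 20 ug/mL in this assay, at which 4 of the 4 values shown sit. The compounds shown leave open what actual value each one has, and whether this change alters it at all.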